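This account rests on a few compounds, and the source may have more. Where it says the series, first, only, none or still open, it means among the compounds named here.

Going by the values given here, in a functional assay on Caco-2 cells (Homo sapiens) for cytotoxicity, read by MTT assay, with a stated time of 48 h (a higher number here means a weaker inhibitor, a lower number a stronger inhibitor), compound 3 (`C[n+]1cccc(OP(=O)([O-])OC[C@H]2O[C@@H](n3cc(F)c(=O)[nH]c3=O)C[C@@H]2OC(=O)c2ccccc2)c1`) gives 1380 nM and shares the low end of the numbers so far with compound 2 (`O=C(O[C@H]1C[C@H](n2cc(F)c(=O)[nH]c2=O)O[C@@H]1COP(=O)(O)Oc1ccc2ncccc2c1)c1ccccc1`), which gives 2460 nM in the same assay. These two values lie within the scatter of each other, so they cannot be ordered. Compound 1 (`CCCCCCCCCc1ccc(OP(=O)(O)OC[C@H]2O[C@@H](n3cc(F)c(=O)[nH]c3=O)C[C@@H]2OC(=O)c2ccccc2)cc1`) gives 20400 nM and lies beyond the scatter from compound 3, on the side of a weaker inhibitor.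

Compound 4 (`CCCCCCCCCC[n+]1cccc(OP(=O)([O-])OC[C@H]2O[C@@H](n3cc(F)c(=O)[nH]c3=O)C[C@@H]2OC(=O)c2ccccc2)c1`), still unmeasured, puts nonyl in place of hydrogen on a saturated chain carbon bound to an aromatic nitrogen, which reads as methyl to decyl. Among the compounds with values here, no two measured compounds differ in one place only, so no measured step gauges this change. Within the data shown here, the only loose guide is compound 1, the one measured compound with a nonyl group, at 20400 nM in this assay even though it also differs from compound 3 elsewhere. A moderate rise in the number is therefore expected, smaller than the gap separating compound 1 and compound 3. The expected move is a 2.5-fold higher number from compound 3 to compound 4 (0.40 log units; beyond the scatter) toward a weaker inhibitor, and this estimate is held loosely. For compound 4 the estimated value is 3500 nM with an expected range of 600 nM to 15000 nM as the working figure.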

Compound 4, half-maximal inhibitory concentration: 12900 nM
The estimate for compound 4 lay 3.7-fold (0.57 log units) below the measured number, and the stated range covers the measured number.
By their numbers in this assay, from the lowest: compounds 3 and 2 (each within the scatter of the next); then compounds 4 and 1 (each within the scatter of the next).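

Going by these compounds alone, compound 3 and compound 4 form the first pair that differ in one place only, so the effect of nonyl in place of hydrogen on a saturated chain carbon bound to an aromatic nitrogen can now be read directly. In this assay, within the data shown here, this methyl to decyl change gives a 9.3-fold higher number from compound 3 to compound 4 (0.97 log units; beyond the scatter), toward a weaker inhibitor, which shows that the group on the aromatic nitrogen is not a neutral site for this read-out and that the earlier compounds, all differing in more than one place, could not isolate this. No measured evidence bearing on this step is available.

On these data alone, with only methyl and decyl at this position, the shape of the relation between chain length and the number remains open: a butyl or hexyl chain could fall anywhere along the step, and a longer chain such as dodecyl could extend it or level off. Also open, as far as these compounds go, is whether the rise depends on the chain itself or would persist with a terminal amine or carboxylic acid on a chain of the same length.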